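The source may hold more compounds than are shown below. What is called first, only, known or untested is meant among the compounds shown, and "the series" means these compounds.

Measured so far in a functional assay on UO-31 cells (Homo sapiens) for cytotoxicity, read by sulforhodamine B assay, with a stated time of 48 h, tested at 100 uM; on this read-out lower numbers stand for a stronger effect and higher numbers for a weaker effect at the one concentration tested: compound 1 `COc1cc(-c2cc(/C=C/C(=O)c3ccc(N)cc3)[nH]n2)cc(OC)c1OC` gives -93%; compound 2 `COc1ccc(C(=O)/C=C/c2cc(-c3cc(OC)c(OC)c(OC)c3)n[nH]2)cc1` gives -79%.

Compound 2 stands at the higher of the two numbers in this assay, with compound 1 the nearest neighbour and the only other point, the step being a number 14 percentage points higher from compound 1 to compound 2 (beyond the scatter). That single measured step concerns an amino against a methoxy on an aromatic carbon, a different place and different groups from the change now in question.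

Compound 3 `COc1cc(-c2cc(/C=C/C(=O)c3ccc(F)c(F)c3)[nH]n2)cc(OC)c1OC` differs from compound 2 by 3,4-difluorophenyl in place of 4-methoxyphenyl on a carbonyl carbon. Among the compounds with values here, no measured step touches the group on the carbonyl carbon, so there is no direct precedent for this change; the one known step shows that a change of a single aromatic substituent can move this assay by a modest amount beyond the scatter, in either sense. On that basis a step from compound 2 to compound 3 of a number 9 percentage points higher from compound 2 to compound 3 (within the scatter) is expected, with the direction uncertain and the range wide. The estimate for compound 3 in this assay is -70%, between -100% and -20%.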

Compound 3, a percentage reported as activity, at one concentration (the size of the read-out at that concentration, not a potency): -16%
For compound 3 the middle estimate is 54 percentage points below the measured one, and the stated range ends below it.
By their numbers in this assay, from the lowest: compound 1; then compound 2; then compound 3.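

Within the data shown here, the group on the carbonyl carbon proves a far more sensitive place in this assay than the one earlier step suggested: the change to 3,4-difluorophenyl gives a number 63 percentage points higher from compound 2 to compound 3 (beyond the scatter) and a number 77 percentage points higher from compound 1 to compound 3 (beyond the scatter), whereas methoxy in place of amino gave only a number 14 percentage points higher from compound 1 to compound 2 (beyond the scatter). The earlier pair showed that the 4-methoxyphenyl and 4-aminophenyl compounds differ modestly, while compound 3 now shows that this position can also carry a group that leaves the effect much weaker at the one concentration tested, with compound 3 the weakest of the three. Nothing available bears on the reason for this large loss.

The change removes the methoxy or amino group and brings in two fluorines at once, so these three compounds cannot say which part of the exchange matters, and a plain phenyl or a phenyl with a single fluorine on the carbonyl carbon would be needed to separate the two. Also open is whether the strong effect of compound 1 and compound 2 extends to other groups on that ring, such as a hydroxyl or a dimethylamino group, and how any of these compounds compare as full concentration series rather than at one concentration.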